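The compounds below may be only part of what the source reports. "The series", "measured", "known", "first", "only" and "open" are said of these compounds alone.

Compound 1 `Cc1cc(O)c(C2=NN(c3ccc(S(N)(=O)=O)cc3)C(c3ccccc3Cl)C2)cc1Cl` and compound 2 `Cc1cc(O)c(C2=NN(c3ccc(S(N)(=O)=O)cc3)C(/C=C/c3ccccc3)C2)cc1Cl` share one core and differ only in the group on a saturated ring carbon. In a functional assay on NCI-H460 cells (Homo sapiens) for antiproliferative activity, with a stated time of 48 h (on this read-out lower numbers stand for stronger inhibition of growth and higher numbers for weaker inhibition of growth), compound 1 gives 2160 nM, and compound 2 gives 4030 nM in this assay. Compound 1 thus shows the lower of the two numbers, but the step of a 1.9-fold higher number from compound 1 to compound 2 (0.27 log units; within the scatter) is too small to count as a real difference, so the two compounds cannot be ranked against each other.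

Compound 3 `COc1ccc(C2CC(c3cc(Cl)c(C)cc3O)=NN2c2ccc(S(N)(=O)=O)cc2)cc1OC` keeps the same core and changes the same position: 3,4-dimethoxyphenyl in place of 2-chlorophenyl on a saturated ring carbon. Within the data shown here, the one comparison at hand, 2-phenylethenyl in place of 2-chlorophenyl, moved this assay only within its scatter. Among the measured compounds shown here, that is a different replacement than the one leading to compound 3, so it gives only weak guidance, and it points to no large shift in either direction. For compound 3 the step of a 1.3-fold higher number from compound 1 to compound 3 (0.11 log units; within the scatter) is therefore expected to stay small. The estimate for compound 3 in this assay is 2800 nM, with a likely range from 1200 nM to 6500 nM.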

Compound 3, concentration for 50% growth inhibition: 2500 nM
Compound 3: middle estimate off by 1.1-fold (0.05 log units), on the high side; the measured number falls inside the stated range.
By their numbers in this assay, from the lowest: compounds 1, 3 and 2 (each within the scatter of the next).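

Replacing 2-chlorophenyl with 3,4-dimethoxyphenyl adds heavy atoms and hydrogen-bond acceptors, yet in this assay it gives a 1.2-fold higher number from compound 1 to compound 3 (0.06 log units; within the scatter), so this larger change on the saturated ring carbon leaves no readable difference. The comparison with the third group agrees, with 3,4-dimethoxyphenyl in place of 2-phenylethenyl giving a 1.6-fold lower number from compound 2 to compound 3 (0.21 log units; within the scatter), so compounds 1, 2 and 3 cannot be separated on this read-out, and the three groups shown at this position are equivalent within the scatter of the assay. No supporting measurement is available to explain this lack of separation.

All three groups shown at this position contain a six-membered aromatic ring of carbon only, so it remains open whether something quite different there, such as an amine, a carboxylic acid or a small methyl group, would move the number beyond the scatter. The 4-sulfamoylphenyl and 5-chloro-2-hydroxy-4-methylphenyl groups are the same in all three compounds, so these comparisons say nothing about how changes at those places would affect growth inhibition.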